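A longer fluorophenyl chain after two limit values

This account rests on a few compounds, and the source may have more. Where it says the series, first, only, none or still open, it means among the compounds named here.

Measured in a physicochemical assay for solubility, in phosphate buffer; on this read-out lower numbers stand for lower solubility and higher numbers for higher solubility:
Compound 1 `Cc1cc(CNCCCC[C@@H](Nc2cc(C)c(F)c(C)c2)C(=O)NO)ccc1F`: > 5 ug/mL, a limit
Compound 2 `COc1ccc(CNCCCC[C@@H](Nc2cc(C)c(F)c(C)c2)C(=O)NO)cc1`: > 5 ug/mL, a limit

Compound 2 gives only a limit, > 5 ug/mL, so its place on the scale is not known as a number. The evidence so far amounts to the limit of > 5 ug/mL in this assay, at which 2 of the 2 values shown sit. Compound 3 `Cc1cc(N[C@H](CCCCNCCCc2ccc(F)cc2)C(=O)NO)cc(C)c1F` differs from compound 2 by one change: 2-(4-fluorophenyl)ethyl in place of 4-methoxyphenyl on a saturated chain carbon bound to an amine nitrogen. In words, 2-(4-fluorophenyl)ethyl stands in place of 4-methoxyphenyl on a saturated chain carbon bound to an amine nitrogen. Going by the values given here, the only measured step that bears on this change is a step that the two limits leave unreadable from compound 1 to compound 2. That step offers neither a size nor a direction, so no step beyond the scatter is expected in this assay. The expected step is a step that the limit leaves unreadable from compound 2 to compound 3. For compound 3 the estimate is 7 ug/mL, with an expected range of 2.5 ug/mL to 25 ug/mL.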

Compound 3, solubility: > 5 ug/mL
Compound 3 ended at the assay's limit (the forecaster's own chance of this, stated with the estimate: 70%); the middle value lies beyond the limit too.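

In this assay compound 3 gives > 5 ug/mL, which is a limit and not a number. No step can be read among compound 1, compound 2 and compound 3. The compounds shown leave open where each one's actual value lies in this assay, and whether the changes between them shift it at all.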